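Methoxy on the phenyl of compound 1: an untested change

The compounds below may be only part of what the source reports. "The series", "measured", "known", "first", "only" and "open" are said of these compounds alone.

Measured compounds:
compound 1, `COc1cc(/C=C/C(=O)c2cccc(-n3cc(-c4ccccc4)[nH]c3=O)c2)ccc1O`, 5190 nM
compound 2, `O=C(/C=C/c1cccc(O)c1)c1cccc(-n2cc(-c3ccccc3)[nH]c2=O)c1`, 5300 nM
compound 3, `COc1cc(/C=C/C(=O)c2cccc(-n3cc(-c4ccccc4)[nH]c3=O)c2)cc(OC)c1OC`, 1880 nM

In a functional assay on OVCAR-4 cells (Homo sapiens) for inhibition (a higher number here means a weaker inhibitor of growth, a lower number a stronger inhibitor of growth), compound 1 gives the second highest of the three numbers. Its nearest neighbour is compound 2, reached by a 1.0-fold higher number from compound 1 to compound 2 (0.01 log units; within the scatter). Compound 3 gives the lowest number of the three, and the gap from compound 1 lies beyond the scatter.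

Compound 4, `COc1ccc(-c2cn(-c3cccc(C(=O)/C=C/c4ccc(O)c(OC)c4)c3)c(=O)[nH]2)cc1`, differs from compound 1 by methoxy in place of hydrogen on an aromatic carbon, that is, phenyl to 4-methoxyphenyl. Among the compounds with values here, no measured step touches this ring: the one step known alters the aryl on the chain carbon instead. Nothing therefore points to a shift in either direction, and compound 4 is expected to give about 5000 nM, between 2200 nM and 11000 nM, meaning a 1.0-fold lower number from compound 1 to compound 4 (0.02 log units; within the scatter).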

Compound 4, concentration for 50% growth inhibition: 6080 nM
Compound 4: middle estimate off by 1.2-fold (0.08 log units), on the low side; measured number inside the range.
By their numbers in this assay, from the lowest: compound 3; then compounds 1, 2 and 4 (each within the scatter of the next).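

In this assay, the step for methoxy in place of hydrogen on this phenyl, para to a large group, is a 1.2-fold higher number from compound 1 to compound 4 (0.07 log units; within the scatter). Within the data shown here, this is the first measured change on this ring, and compounds 1 and 4 cannot be told apart, so here the added methoxy shows no readable effect on growth inhibition. No evidence on the reason is at hand. The compounds shown leave open whether an amine, a carboxylic acid or a longer alkoxy chain at this place would also leave the number within the scatter.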